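Amide Replacement on a Shared Core: From Chlorophenyl to Benzothiophene

The source may hold more compounds than are shown below. What is called first, only, known or untested is meant among the compounds shown, and "the series" means these compounds.

Of the compounds shown here, three on one shared core have been measured in a functional assay on HepG2 cells (Homo sapiens) for cytotoxicity, read by MTT assay, with a stated time of 72 h; a lower number here means a stronger inhibitor, a higher number a weaker inhibitor. Compound 1 `CN1[C@@H]2c3[nH]c4ccccc4c3C[C@H]1[C@H](C#N)N1[C@@H](CN3C(=O)c4ccccc4C3=O)c3[nH]c4ccccc4c3C[C@@H]21` gives 20 nM, compound 2 `CN1[C@@H]2c3[nH]c4ccccc4c3C[C@H]1[C@H](C#N)N1[C@@H](CNC(=O)c3ccc(Cl)cc3)c3[nH]c4ccccc4c3C[C@@H]21` gives 350 nM, and compound 3 `CN1[C@@H]2c3[nH]c4ccccc4c3C[C@H]1[C@H](C#N)N1[C@@H](CNC(=O)c3ccc4ccccc4c3)c3[nH]c4ccccc4c3C[C@@H]21` gives 1210 nM. Compound 2 therefore stands second highest of the three numbers: the step of an 18-fold higher number from compound 1 to compound 2 (1.24 log units; beyond the scatter) is large, while the step of a 3.5-fold higher number from compound 2 to compound 3 (0.54 log units; beyond the scatter) is modest. Compound 4 `CN1[C@@H]2c3[nH]c4ccccc4c3C[C@H]1[C@H](C#N)N1[C@@H](CNC(=O)c3cc4ccccc4s3)c3[nH]c4ccccc4c3C[C@@H]21` has not yet been measured in this assay. It differs from compound 2 in one place: 1-benzothiophen-2-yl in place of 4-chlorophenyl on a carbonyl carbon. Among the measured compounds shown here, of the measured steps, only the one from compound 2 to compound 3 bears on this change, since it also exchanges 4-chlorophenyl on the carbonyl carbon for a larger aromatic group, and that exchange raised the number by a 3.5-fold higher number from compound 2 to compound 3 (0.54 log units; beyond the scatter). A step of similar size and the same direction is therefore expected for compound 4, written as a 2.6-fold higher number from compound 2 to compound 4 (0.41 log units; beyond the scatter). On that basis compound 4 is estimated to give 900 nM in this assay, within a range from 300 nM to 3000 nM.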

Compound 4, half-maximal inhibitory concentration: 300 nM
The estimate for compound 4 lay 3.0-fold (0.48 log units) above the measured number; the measured number falls inside the stated range.
By their numbers in this assay, from the lowest: compound 1; then compounds 4 and 2 (each within the scatter of the next); then compound 3.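

In this assay, placing 1-benzothiophen-2-yl instead of 4-chlorophenyl on the carbonyl carbon gives a 1.2-fold lower number from compound 2 to compound 4 (0.07 log units; within the scatter), so a larger aromatic group at this position does not necessarily raise the number as naphthalen-2-yl did. The two larger groups also do not behave alike, as the exchange of naphthalen-2-yl for 1-benzothiophen-2-yl gives a 4.0-fold lower number from compound 3 to compound 4 (0.61 log units; beyond the scatter), which shows that the identity of the aromatic group matters here, not just the fact that it is larger than 4-chlorophenyl. The new amide does not close the large gap to the group carried by compound 1, with a 15-fold higher number from compound 1 to compound 4 (1.18 log units; beyond the scatter).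

No measurement available here accounts for these differences. The compounds shown leave open how a cyclohexyl group, a pyridine ring or a carboxylic acid on the aromatic group would fare on the carbonyl carbon in this assay.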